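This account rests on a few compounds, and the source may have more. Where it says the series, first, only, none or still open, it means among the compounds named here.

Measured compounds in a physicochemical assay for lipophilicity, in phosphate buffer, measured as octanol-water partition, with a stated time of 24 h; on this read-out higher numbers stand for higher lipophilicity and lower numbers for lower lipophilicity:
- compound 1, `S=C(N/N=C/c1ccc(Oc2ccc3ccccc3c2)cc1)Nc1ccc(Cl)cc1`: 6.96
- compound 2, `S=C(N/N=C/c1ccc(Oc2ccc(Cl)cc2)cc1)Nc1ccccc1`: 5.52
- compound 3, `S=C(N/N=C/c1ccc(Oc2ccccc2)cc1)Nc1ccc(Cl)cc1`: 5.64

Compound 2 gives the lowest of the three numbers in this assay. Compound 3 sits closest to it, within the scatter, so the two are not told apart. Compound 1 lies furthest away, beyond the scatter.

Compound 4, `O=[N+]([O-])c1ccc(Oc2ccc(/C=N/NC(=S)Nc3ccccc3)cc2)cc1`, has not yet been measured. It differs from compound 2 in one place: nitro in place of chloro on an aromatic carbon.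

Going by the values given here, only one step between measured compounds is available, a number 1.32 log units lower from compound 1 to compound 3 (beyond the scatter), and it concerns an exchange of the aryl group on the ether oxygen, not the substituent on the outer ring of the thiourea side. Among the compounds with values here, no measured pair exchanges chloro for nitro, so the step from compound 2 to compound 4 has no direct precedent here; the expectation rests on the structural change alone.

The change is expected to lower the number in this assay, estimated as a number 0.92 log units lower from compound 2 to compound 4 (beyond the scatter). For compound 4 the estimate is 4.6, with a range from 3.9 to 5.3.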

Compound 4, partition coefficient: 4.95
For compound 4 the middle estimate is 0.35 log units below the measured one; the measured number falls inside the stated range.
By their numbers in this assay, from the lowest: compound 4; then compounds 2 and 3 (each within the scatter of the next); then compound 1.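

In this assay, going by these compounds alone, the exchange of 4-chlorophenyl for 4-nitrophenyl gives a number 0.57 log units lower from compound 2 to compound 4 (beyond the scatter), the first reading of a substituent exchange on this aromatic carbon, para to a large group. Within the data shown here, the only earlier step, a number 1.32 log units lower from compound 1 to compound 3 (beyond the scatter), concerned the aryl group on the ether oxygen, so it said nothing about this position; the new step shows that the number responds to the group placed here, by a modest amount that still lies beyond the scatter. Nitro carries hydrogen-bond acceptors and more heavy atoms than chloro, but no measurement at hand bears on why the number falls, and this single pair cannot separate those differences from one another.

With only chloro and nitro represented at this position, the compounds shown give no trend across substituents, and it remains open where an amine, a carboxylic acid or a longer chain such as propyl would fall in this assay. Also open, on these data alone, is whether the same exchange would give a step of similar size in a compound other than compound 2, since the series holds just this one chloro to nitro pair.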